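The source may report more compounds than this note shows. Statements on the series, on what has been measured and on what is new or still open speak of the compounds shown alone.

Compound 2 `C=Cc1cc(C(F)(F)F)cc(C(F)(F)F)c1` stands at one of the two limits seen here: in an ADME assay for pharmacokinetics, read by HPLC, in phosphate buffer, with a stated time of 72 h, at pH 7.4, tested at 250 uM (a lower number here means that the compound disappears faster, a higher number that the compound lasts longer), compound 2 gives > 50 h, a limit rather than a number. Compound 3 `Fc1cc(C(F)(F)F)cc(C(F)(F)F)c1` likewise gives > 50 h, again a limit. Compound 1 `C=CS(=O)(=O)c1cc(C(F)(F)F)cc(C(F)(F)F)c1` sits at the other end, where compound 1 gives < 0.017 h, also a limit. Accordingly an at least 2900-fold higher number from compound 1 to compound 2 (3.46 log units; beyond the scatter) and an at least 2900-fold higher number from compound 1 to compound 3 (3.46 log units; beyond the scatter), whereas a step that the two limits leave unreadable from compound 2 to compound 3. Compound 4 `FC(F)(F)c1cc(S)cc(C(F)(F)F)c1` differs from compound 2 by sulfanyl in place of vinyl on an aromatic carbon. For the measured compounds named here, no measured step exchanges the vinyl for a sulfanyl group; the only step that removes the vinyl is unreadable, and both readable steps concern the vinylsulfonyl group of compound 1. The number for compound 4 is therefore expected as 30 h (4 h to 50 h). That estimate means an at least 1.6-fold lower number from compound 2 to compound 4 (0.22 log units; that floor lies within the scatter), expected downward, with its size uncertain.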

Compound 4, half-life: > 50 h
Compound 4 ended at the assay's limit; the forecaster's own chance of this, stated with the estimate: 45%; middle value at least 1.6-fold (0.22 log units) away from the limit.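

In this assay compound 4 gives > 50 h, which is a limit. The change from vinylsulfonyl to sulfanyl gives an at least 2900-fold higher number from compound 1 to compound 4 (3.46 log units; beyond the scatter), so the fast disappearance now stands against three replacements on this aromatic carbon, not two. The steps among the compounds at the upper limit cannot be read, so vinyl, fluoro and sulfanyl cannot be ranked: the limit of > 50 h in this assay, at which 3 of the 4 values shown sit.

Open, on these data alone, is how long any of these three lasts beyond that limit. Also open, as far as these compounds go, is whether a methylsulfonyl group, which keeps the sulfonyl and loses the vinyl, or an amine on this carbon would disappear as fast as compound 1 does.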